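Swapping methyl for chloro on the aryl ether of compound 1

The source may hold more compounds than are shown below. What is called first, only, known or untested is meant among the compounds shown, and "the series" means these compounds.

Measured so far:
compound 1 `CCN(Cc1cccs1)C(=O)COc1ccc(C)cc1`: 8 nM
compound 2 `Cc1ccc(OCC(=O)N(Cc2cccs2)C2COC2)cc1`: 23000 nM
compound 3 `CCN(Cc1ccccc1)C(=O)COc1ccc(C)cc1`: 1880 nM

In an assay on HEK293 cells for agonist activity at transient receptor potential cation channel subfamily M member 8 (Homo sapiens), read by fluorescence and calcium flux, with a stated time of 15 min (a higher number here means that more compound is needed for the effect, a lower number that less compound is needed), compound 1 gives the lowest number of the three, with compound 3 nearest and compound 2 furthest. The steps seen so far are large: a 2900-fold higher number from compound 1 to compound 2 (3.46 log units; beyond the scatter) and a 240-fold higher number from compound 1 to compound 3 (2.37 log units; beyond the scatter). Both change the amide side of the molecule, not the aryl ether. Compound 4 `CCN(Cc1cccs1)C(=O)COc1ccc(Cl)cc1` differs from compound 1 by chloro in place of methyl on an aromatic carbon. Within the data shown here, no measured step touches this part of the core of compound 1, so there is no direct guide; both replacements keep the same count of heavy atoms and add no donor or acceptor. The expected step is a 1.9-fold higher number from compound 1 to compound 4 (0.27 log units; within the scatter), within scatter. Compound 4 is estimated at 15 nM, with a range from 3 nM to 80 nM.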

Compound 4, half-maximal effective concentration: 39 nM
The estimate for compound 4 lay 2.6-fold (0.41 log units) below the measured number, and the stated range covers the measured number.
By their numbers in this assay, from the lowest: compound 1; then compound 4; then compound 3; then compound 2.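

In this assay the aryl ether side of the molecule is shown to matter too: chloro in place of methyl on this aromatic carbon gives a 4.9-fold higher number from compound 1 to compound 4 (0.69 log units; beyond the scatter) even though only one heavy atom is exchanged. This step is much smaller than the two amide-side steps from compound 1, yet it lies beyond the scatter, so methyl is preferred over chloro here. Nothing measured here bears on why the number rises.

From the compounds shown here alone, whether fluoro, methoxy or a carboxylic acid on this carbon would give a lower number than compound 1 remains open. So does whether the methyl-to-chloro step keeps its size when the amide side changes.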